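A few compounds are considered here, and "the series" means these few. Any claim that something is new, unique, unknown or untested is made for them only; others in the source may bear on it.

Measured compounds:
compound 1, `Cc1c(-c2ccccc2)sc(N)c1C(=O)c1ccc(Cl)cc1`, 1%
compound 2, `CC(C)(C)Cc1c(-c2ccccn2)sc(N)c1C(=O)c1ccc(Cl)cc1`, 1%

Both measured compounds were tested in an assay on CHO cells for displacement of a labelled ligand from adenosine receptor A3 (Homo sapiens), read by scintillation counting, tested at 10 uM; on this read-out lower numbers stand for less inhibition and higher numbers for more inhibition at the one concentration tested (going by the name of the read-out). Compound 1 gives 1% and compound 2 gives 1%, so compound 2 stands level with compound 1 at the digits shown; the two values lie within the scatter of each other and show no order. Both numbers sit at the very bottom of the scale, so neither compound shows any inhibition worth the name at the one concentration tested.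

The unmeasured compound 3, `Cc1ccc(-c2sc(N)c(C(=O)c3ccc(Cl)cc3)c2CC(C)(C)C)cc1`, differs from compound 2 in one place: 4-methylphenyl in place of pyridin-2-yl on an aromatic carbon. For the measured compounds named here, no step between measured compounds is known for this exchange, so the expectation for compound 3 rests only on the shared core and on the fact that compound 1, which carries a plain phenyl at the same position together with a methyl rather than a neopentyl, gives 1% in this assay. Because compound 2 gives 1%, the step from compound 2 to compound 3 is expected to be none beyond the scatter, a number 2 percentage points higher from compound 2 to compound 3 (within the scatter). Compound 3 is therefore estimated at 3%, within a range from -5% to 15%.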

Compound 3, a percentage reported as inhibition, at one concentration (the size of the read-out at that concentration, not a potency): 1%
Beside the measured number, compound 3's estimate is 2 percentage points above it; low and high end bracket the measured number.
By their numbers in this assay, from the lowest: compounds 1, 2 and 3 (each within the scatter of the next).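

For the compounds shown here, putting 4-methylphenyl in place of pyridin-2-yl, on the aromatic carbon next to the ring sulfur, gives no change at the digits printed from compound 2 to compound 3 (within the scatter) in this assay, and this is the first step that can be read at this position. The ring nitrogen, with its one hydrogen-bond acceptor, leaves and a carbon-only ring enters, yet the read-out stays at the very bottom of the scale, so neither aromatic group at this place brings out inhibition worth the name at the one concentration tested on this neopentyl-bearing core. Nothing in the available data explains these numbers.

With both compounds at the bottom of the scale, the step cannot tell whether this exchange would matter on a compound that shows real inhibition, so it does not establish that the position is indifferent to what it carries. On these data alone, whether a carboxylic acid or a piperidine at this place, or a longer chain in place of the neopentyl group, would give a higher number in this assay remains open.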